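Swapping the Aryl Group on a Calcium Channel Inhibitor Series

A few compounds are considered here, and "the series" means these few. Any claim that something is new, unique, unknown or untested is made for them only; others in the source may bear on it.

Among the three compounds measured in a functional assay on IMR-32 cells for inhibition of Voltage-dependent N-type calcium channel subunit alpha-1B (Homo sapiens), read by calcium flux (a lower number here means a stronger inhibitor, a higher number a weaker inhibitor), compound 3 `CC1=NC(C)=C(C(=O)O)C(c2cccc(Br)c2)/C1=C(\O)OC/C=C/c1ccccc1` stands lowest with 790 nM; compound 2 `CC1=NC(C)=C(C(=O)O)C(c2ccccc2)/C1=C(\O)OC/C=C/c1ccccc1` gives 2000 nM and compound 1 `CC1=NC(C)=C(C(=O)O)C(c2ccc([N+](=O)[O-])cc2)/C1=C(\O)OC/C=C/c1ccccc1` gives 21000 nM. Compound 4 `CC1=NC(C)=C(C(=O)O)C(c2ccsc2)/C1=C(\O)OC/C=C/c1ccccc1` differs from compound 3 by thiophen-3-yl in place of 3-bromophenyl on a saturated ring carbon. Going by the values given here, no measured step exchanges one aromatic ring for another of this kind; the steps that bear on this position are a 2.5-fold lower number from compound 2 to compound 3 (0.40 log units; beyond the scatter) and a 27-fold lower number from compound 1 to compound 3 (1.42 log units; beyond the scatter), while an 11-fold lower number from compound 1 to compound 2 (1.02 log units; beyond the scatter). The thiophen-3-yl group carries no bromine, so part of the gain seen in a 2.5-fold lower number from compound 2 to compound 3 (0.40 log units; beyond the scatter) is expected to be given back. Compound 4 is thus expected to show a 1.9-fold higher number from compound 3 to compound 4 (0.28 log units; within the scatter). Compound 4 is estimated at 1500 nM, within 500 nM to 5000 nM.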

Compound 4, half-maximal inhibitory concentration: 2900 nM
Beside the measured number, compound 4's estimate is 1.9-fold (0.29 log units) below it; the measured number falls inside the stated range.
By their numbers in this assay, from the lowest: compound 3; then compounds 2 and 4 (each within the scatter of the next); then compound 1.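

Thiophen-3-yl on the saturated ring carbon reads as phenyl does, with a 1.5-fold higher number from compound 2 to compound 4 (0.16 log units; within the scatter) and no order between the two, so a five-membered aromatic ring with sulfur can stand in for the six-membered ring of carbon only. It does not match 3-bromophenyl, with a 3.7-fold higher number from compound 3 to compound 4 (0.56 log units; beyond the scatter) in this assay, yet it stays well ahead of 4-nitrophenyl, with a 7.2-fold lower number from compound 1 to compound 4 (0.86 log units; beyond the scatter). Nothing measured here accounts for these steps. On these data alone, it remains open whether a bromo group on the thiophen-3-yl ring would bring the gain it brings on phenyl, and whether furan-3-yl or thiophen-2-yl would read like thiophen-3-yl.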